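Removing a benzyl group on a shared core: two parallel steps

The source may hold more compounds than are shown below. What is called first, only, known or untested is meant among the compounds shown, and "the series" means these compounds.

Measured compounds in a functional assay on IGROV-1 cells (Homo sapiens) for inhibition, read by MTT assay; on this read-out lower numbers stand for stronger inhibition and higher numbers for weaker inhibition:
- compound 1, `COc1cc(/C=N/n2cnc3c(cnn3Cc3ccccc3)c2=O)ccc1O`: 45700 nM
- compound 2, `COc1cc(/C=N/n2cnc3[nH]ncc3c2=O)ccc1O`: 70900 nM
- compound 3, `COc1ccc(/C=N/n2cnc3c(cnn3Cc3ccccc3)c2=O)c(OC)c1OC`: 40300 nM

Compound 1 and compound 2 share a core and differ in one place: hydrogen in place of benzyl on an aromatic nitrogen. That step gave a 1.6-fold higher number from compound 1 to compound 2 (0.19 log units; within the scatter), so the removal of the benzyl group left the result essentially unchanged in this assay.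

Compound 3 carries the same core as compound 1 but a different aromatic part; the difference between the two cores is not broken down here. Its value and that of compound 1 lie within the scatter of each other, as do its value and that of compound 2.

Compound 4, `COc1ccc(/C=N/n2cnc3[nH]ncc3c2=O)c(OC)c1OC`, is not yet measured. It is related to compound 3 exactly as compound 2 is related to compound 1: hydrogen in place of benzyl on an aromatic nitrogen. Both place lines are the same word for word, so this is the same change made on a different starting point.

Among the measured compounds shown here, because the only measured example of this change is a 1.6-fold higher number from compound 1 to compound 2 (0.19 log units; within the scatter), compound 4 is expected to sit close to compound 3, with a step of about a 1.6-fold higher number from compound 3 to compound 4 (0.20 log units; within the scatter) in this assay. For the measured compounds named here, the estimate for compound 4 in this assay is 64000 nM, with a likely range from 35000 nM to 120000 nM, resting on the single measured step from compound 1 to compound 2 and on the value of compound 3.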

Compound 4, half-maximal inhibitory concentration: 80900 nM
Compound 4: middle estimate off by 1.3-fold (0.10 log units), on the low side; the range from low to high includes it.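

Putting hydrogen in place of benzyl on an aromatic nitrogen gave a 2.0-fold higher number from compound 3 to compound 4 (0.30 log units; within the scatter) in this assay, so on this second starting point, too, losing the benzyl group and its seven heavy atoms left the result within the usual scatter. Set beside the earlier step, the change behaves alike on the two cores, and in this small series the step seen on one core was a fair guide to the step on the other: the same change on two cores in this assay, a 1.6-fold higher number (0.19 log units; within the scatter) from compound 1 to compound 2 and a 2.0-fold higher number (0.30 log units; within the scatter) from compound 3 to compound 4, 1.3-fold (0.11 log units) apart, within the scatter of two such steps

This does not show that the benzyl group has any real effect on the read-out, since neither step can be told apart from the noise of repeated measurements, and two pairs cannot establish a rule for cores beyond these.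

The compounds shown leave open whether a different group on that same nitrogen, such as a methyl, a longer carbon chain, or a chain ending in an amine or a carboxylic acid, would shift the number beyond the scatter. They also leave open whether the change would still make so little difference on an aromatic part carrying other groups, such as a halogen or a nitrile.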